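Shortening the Alkyne Chain on a Nucleoside Core

A few compounds are considered here, and "the series" means these few. Any claim that something is new, unique, unknown or untested is made for them only; others in the source may bear on it.

Measured so far:
compound 1, `CCC#C[C@@]1(O)[C@@H](CO)O[C@@H](n2ccc(N)nc2=O)[C@@H]1O`: 108000 nM
compound 2, `C#CC[C@]1(O)[C@@H](CO)O[C@@H](n2ccc(=O)[nH]c2=O)[C@@H]1O`: > 350000 nM

Of the compounds shown here, two have been measured in a functional assay on KB cells (Homo sapiens), read by MTT assay; a higher number here means a weaker inhibitor, a lower number a stronger inhibitor. For the measured compounds named here, compound 1 gives 108000 nM, and this is the only actual number among the values shown. Compound 2 reaches only a limit of the assay, > 350000 nM, so no number is available for it. The evidence thus amounts to the limit of > 350000 nM in this assay, at which 1 of the 2 values shown sits, with one of the two values sitting there.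

The unmeasured compound 3, `CC#C[C@@]1(O)[C@@H](CO)O[C@@H](n2ccc(N)nc2=O)[C@@H]1O`, shares the core of compound 1 and differs from it in one place: hydrogen in place of methyl on a saturated chain carbon bound to a triple-bonded carbon. Going by the values given here, no step between two measured compounds with a shared difference is available, so the size of this step must be judged from the change itself. Removing one carbon from a saturated chain bound to a triple-bonded carbon is a small change, and no value here suggests a large effect in either direction.

Compound 3 is therefore expected to stay close to compound 1, with a step of a 1.4-fold higher number from compound 1 to compound 3 (0.14 log units; within the scatter) that may lie within the scatter. Compound 3 is estimated at 150000 nM, within a range of 50000 nM to 450000 nM.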

Compound 3, half-maximal inhibitory concentration: 14600 nM
Estimate against measurement, compound 3: 10-fold (1.01 log units) above, and the stated range ends above it.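

In this assay, replacing but-1-yn-1-yl with prop-1-yn-1-yl on the shared core gives a 7.4-fold lower number from compound 1 to compound 3 (0.87 log units; beyond the scatter). For the compounds shown here, this is the first step read between two measured compounds that differ in one place, and it lies beyond the scatter, so this position is not indifferent to the change: the loss of a single methyl from the saturated chain carbon bound to a triple-bonded carbon is enough to move the read-out, and the shorter chain is the better of the two here. Nothing among the measured data accounts for why this small change has an effect of this size.

Going by these compounds, the direction rests on this one pair alone, so it remains open whether the trend continues to an ethynyl group on the same core or reverses with a longer chain such as pent-1-yn-1-yl. On these data alone, it also remains open whether the chain end tolerates an amine or a hydroxyl group in place of the hydrogen, and whether the same shortening would have a comparable effect on a different base.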